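Fluoro to chloro on the cyclopropyl amide

A few compounds are considered here, and "the series" means these few. Any claim that something is new, unique, unknown or untested is made for them only; others in the source may bear on it.

In an ADME assay on Huh-7 cells (Homo sapiens) for cytotoxicity, with a stated time of 3 days (a lower number here means that less compound is tolerated, a higher number that more compound is tolerated), compound 1 `Nc1ccccc1NC(=O)c1c(NO)cc(-c2ccccc2)oc1=O` gives > 20000 nM, which is a limit. Compound 2 `O=C(NC1CC1)c1c(NO)cc(-c2ccc(F)cc2)oc1=O` gives > 20000 nM, also a limit and not a number. Compound 3 `O=C(NC1CCCCC1)c1c(NO)cc(-c2ccc(F)cc2)oc1=O` gives 11400 nM. Compound 4 `O=C(NC1CC1)c1c(NO)cc(-c2ccc(Cl)cc2)oc1=O` differs from compound 2 by chloro in place of fluoro on an aromatic carbon, a change from 4-fluorophenyl to 4-chlorophenyl. For the measured compounds named here, the only measured step, an at least 1.7-fold lower number from compound 2 to compound 3 (0.24 log units; that floor lies within the scatter), is cyclohexyl in place of cyclopropyl on an amide-type nitrogen, which is a different place. Going by the values given here, no measured step covers a change on the aromatic carbon, so no step beyond the scatter is expected in this assay. The expected step is a number no higher from compound 2 to compound 4 (the limit leaves the size open). For compound 4 the estimated value is 20000 nM, with an expected range of 10000 nM to 40000 nM.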

Compound 4, half-maximal cytotoxic concentration: 12800 nM
Estimate against measurement, compound 4: 1.6-fold (0.19 log units) above, within the range that was stated.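

Chloro in place of fluoro, on an aromatic carbon para to a large group, is the first change at this position that can be read in this assay, and it gives an at least 1.5-fold lower number from compound 2 to compound 4 (0.19 log units; that floor lies within the scatter). Compound 4 carries a measured number where compound 2 carries a limit, so a change away from the amide nitrogen also yields a measured value. The size of the step stays open because it starts from a limit: the limit of > 20000 nM in this assay, at which 2 of the 4 values shown sit.

Going by these compounds, whether the true step lies beyond the scatter remains open. Also open, on these data alone, is what an amine or a methoxy group on this aromatic carbon gives on the cyclopropyl amide.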